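This account rests on a few compounds, and the source may have more. Where it says the series, first, only, none or still open, it means among the compounds named here.

Compound 2 `N#C/C(=C\N1CCN(C(=O)c2ccco2)C1=S)C(N)=O` stands with the higher of the two numbers recorded so far in a functional assay on HT-29 cells (Homo sapiens) for inhibition, read by sulforhodamine B assay, with a stated time of 48 h (a lower number here means a stronger inhibitor of growth, a higher number a weaker inhibitor of growth), where compound 2 gives 24100 nM. Its nearest neighbour is compound 1 `N#C/C(=C\N1CCN(C(=O)c2ccco2)C1=S)C(=O)Nc1ccc(Cl)cc1`, which in this assay gives 21400 nM; the move a 1.1-fold higher number from compound 1 to compound 2 (0.05 log units; within the scatter) came with hydrogen in place of 4-chlorophenyl on an amide-type nitrogen. Compound 3 `N#C/C(=C\N1CCN(C(=O)c2ccco2)C1=S)C(=O)c1ccccc1` follows from compound 2 by phenyl in place of amino on a carbonyl carbon, so that carbamoyl becomes benzoyl on the carbon double-bonded to the chain. Among the measured compounds shown here, no measured pair shows exactly this change; the only step recorded, from compound 1 to compound 2, shows that what hangs on that amide-type nitrogen hardly moved the number. The shared core and the rest of the molecule are kept. On that basis compound 3 is expected to give a number in this assay close to that of compound 2, a step of about a 1.2-fold lower number from compound 2 to compound 3 (0.08 log units; within the scatter). The estimate for compound 3 in this assay is therefore 20000 nM, with a range from 7000 nM to 55000 nM.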

Compound 3, concentration for 50% growth inhibition: 30500 nM
Compound 3: the middle estimate sits 1.5-fold (0.18 log units) below what was measured; measured number inside the range.
By their numbers in this assay, from the lowest: compounds 1, 2 and 3 (each within the scatter of the next).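

Until now only what hangs on the amide-type nitrogen had changed, whereas here the nitrogen itself leaves the carbonyl carbon: a 1.3-fold higher number from compound 2 to compound 3 (0.10 log units; within the scatter) and a 1.4-fold higher number from compound 1 to compound 3 (0.15 log units; within the scatter) in this assay. So the position tolerates the loss of that nitrogen, and with it the hydrogen-bond donor of amino, as well as the entry of a six-membered aromatic ring directly on the carbonyl carbon, with every step still within the scatter. No measurement shown here offers an explanation for this flat result. Still open, from the compounds shown here alone, is whether a different group on that carbonyl carbon, such as a methyl, a hydroxyl as in a carboxylic acid, or a cyclic amine such as morpholin-4-yl, would move the number beyond the scatter. Going by these compounds, the shared core is the same in all three compounds, so its share in the growth inhibition also remains open.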